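Adding a Cyclohexyl Ring to an Inactive Amine

The source may report more compounds than this note shows. Statements on the series, on what has been measured and on what is new or still open speak of the compounds shown alone.

Compound 2 `Cc1ncc(CO)c2c(Nc3ccccn3)c(N)oc12` carries a free amino group on its shared core. In a functional assay on HEK293 cells for agonist activity at Toll-like receptor 8 (Homo sapiens), read by reporter gene assay (on this read-out lower numbers stand for an effect already at smaller amounts and higher numbers for an effect only at larger amounts of compound), compound 2 is reported as "not active" (no number reported), so no number exists to place it against the others. Compound 1 `CCCCCNc1oc2c(C)ncc(CO)c2c1Nc1cccc([N+](=O)[O-])c1` gives 850 nM and compound 3 `CCCCCNc1oc2c(C)ncc(CO)c2c1Nc1ccccc1` gives 2250 nM; both carry an alkyl chain on the corresponding nitrogen. Among the compounds with values here, the one measured step, a 2.6-fold higher number from compound 1 to compound 3 (0.42 log units; beyond the scatter), concerns a different position and does not bear on the change at hand. Compound 4 `Cc1ncc(CO)c2c(Nc3ccccn3)c(NC3CCCCC3)oc12` differs from compound 2 by cyclohexyl in place of hydrogen on a nitrogen on an aromatic ring. Within the data shown here, no measured pair shows this change, so its size and direction are unknown; the only guide is that the two compounds bearing a substituent on that nitrogen gave numbers at all. Compound 4 is estimated to give 2500 nM, within a range from 500 nM to 15000 nM.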

Compound 4, half-maximal effective concentration: 6930 nM
Compound 4: middle estimate off by 2.8-fold (0.44 log units), on the low side; the measured number falls inside the stated range.
By their numbers in this assay, from the lowest: compound 1; then compound 3; then compound 4.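

Within the data shown here, compound 2 has no number, so no step to compound 4 can be read. The compounds shown leave open how cyclohexyl compares with other groups on that nitrogen. Nothing shown here offers an explanation for the value of compound 4.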